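This account rests on a few compounds, and the source may have more. Where it says the series, first, only, none or still open, it means among the compounds named here.

In a functional assay on HeLa cells (Homo sapiens) for antiproliferative activity, read by MTT assay, with a stated time of 48 h (a lower number here means a stronger inhibitor, a higher number a weaker inhibitor), compound 1 `COc1cc(-c2nnc3c(OC(C)C)cc(-c4ccc5[nH]ccc5c4)cn23)cc(OC)c1OC` gives 261 nM. Compound 2 `COc1cc(-c2nnc3c(OC4CCC4)cc(-c4ccc5[nH]ccc5c4)cn23)cc(OC)c1OC` gives 142 nM, and these two values lie within the scatter of each other, so neither can be ranked over the other. Compound 3 `COc1cc(-c2nnc3c(OC4CN(C(C)(C)C)C4)cc(-c4ccc5[nH]ccc5c4)cn23)cc(OC)c1OC` returns only a limit of the assay, > 10000 nM.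

Compound 4 `COc1cc(-c2nnc3c(OC(C)C)cc(-c4ccc5c(ccn5C)c4)cn23)cc(OC)c1OC` keeps the core of compound 1 and its isopropyl group on oxygen. It differs at one place, (methyl in place of hydrogen on an aromatic nitrogen), with methyl in place of hydrogen on an aromatic nitrogen, so that 1H-indol-5-yl becomes 1-methyl-1H-indol-5-yl.

Within the data shown here, no measured step touches that nitrogen. Both steps starting from compound 1 change the group on an oxygen on an aromatic ring. Cyclobutyl in place of isopropyl gives a 1.8-fold lower number from compound 1 to compound 2 (0.26 log units; within the scatter), while 1-(tert-butyl)azetidin-3-yl in place of isopropyl gives an at least 38-fold higher number from compound 1 to compound 3 (1.58 log units; beyond the scatter). The same azetidinyl group in place of cyclobutyl gives an at least 70-fold higher number from compound 2 to compound 3 (1.84 log units; beyond the scatter). These steps show how far the numbers can move at the oxygen, but they give no direction for a change at the nitrogen. In this assay, therefore, no step beyond the scatter is expected, although the uncertainty is wide. The expected step is a 1.3-fold lower number from compound 1 to compound 4 (0.12 log units; within the scatter). For compound 4 the estimated value is 200 nM, with an expected range from 50 nM to 1000 nM.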

Compound 4, half-maximal inhibitory concentration: 503 nM
For compound 4 the middle estimate is 2.5-fold (0.40 log units) below the measured one, within the range that was stated.
By their numbers in this assay, from the lowest: compounds 2, 1 and 4 (each within the scatter of the next, the first and the last beyond it). At a limit, above all of these: compound 3.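

This is the first change shown at the aromatic nitrogen of the five-membered aromatic ring, and in this assay methyl in place of hydrogen there gives a 1.9-fold higher number from compound 1 to compound 4 (0.28 log units; within the scatter). With the isopropyl group on oxygen held constant, compound 4 cannot be ranked against compound 1, so in this one pair the hydrogen on that nitrogen is not needed to keep the value within the scatter, and the position accepts a methyl group without a measurable loss. Nothing measured here bears on why this step stays so small.

The compounds shown leave open whether a group larger than methyl on this nitrogen, such as an ethyl group, a longer chain ending in an amine, or a chain ending in a carboxylic acid, would also stay within the scatter of compound 1. They also leave open whether methyl on this nitrogen would give a similar step when the group on oxygen is the cyclobutyl of compound 2 or the 1-(tert-butyl)azetidin-3-yl of compound 3.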